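Swapping the aryl group on compound 1's amide

The source may report more compounds than this note shows. Statements on the series, on what has been measured and on what is new or still open speak of the compounds shown alone.

Measured compounds:
- compound 1, `Cc1cc(NC(=O)CN2CCC(c3cccc[n+]3[O-])CC2)ccc1F`, 75%
- compound 2, `CCOc1cccc(C(=O)NCN2CCC(c3cccc[n+]3[O-])CC2)c1`, 54%
- compound 3, `O=C(NCN1CCC(c2cccc[n+]2[O-])CC1)c1ccc2ccccc2c1`, 67%

All three were tested in a functional assay on HEK293 cells for agonist activity at D(4) dopamine receptor (Homo sapiens), read by FLIPR; on this read-out lower numbers stand for smaller maximal responses and higher numbers for larger maximal responses. Compound 1 gives 75%, the highest of the three numbers. Compound 3, with 67%, sits within the usual scatter of compound 1, so the two cannot be told apart. Compound 2, with 54%, lies beyond the scatter below compound 1. No pair among these differs in only one place, so no single change can be tied to a measured step.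

Compound 4, `CSc1cccc(NC(=O)CN2CCC(c3cccc[n+]3[O-])CC2)c1`, has not yet been measured in this assay. It differs from compound 1 in one place: 3-(methylsulfanyl)phenyl in place of 4-fluoro-3-methylphenyl on an amide-type nitrogen. The shared core is untouched.

For the measured compounds named here, with no measured step of this kind to lean on, the only guide is that the entering and leaving groups are of the same size and both ring-shaped. The expected change is therefore small, most likely within the scatter, and if anything slightly downward. Compound 4 is estimated to reach 68%, in a range of 50% to 85%, which corresponds to an expected step of a number 7 percentage points lower from compound 1 to compound 4 (within the scatter).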

Compound 4, largest response reached (reported as efficacy), in percent of the reference or control that the assay uses: 56%
Compound 4: middle estimate off by 12 percentage points, on the high side, and the stated range covers the measured number.
By their numbers in this assay, from the lowest: compounds 2 and 4 (each within the scatter of the next); then compounds 3 and 1 (each within the scatter of the next).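

Swapping 4-fluoro-3-methylphenyl for 3-(methylsulfanyl)phenyl on the amide-type nitrogen gives the first change in one place that can be read in this assay, and it amounts to a number 19 percentage points lower from compound 1 to compound 4 (beyond the scatter) in the size of the maximal response. The two groups have the same count of heavy atoms and the same single six-membered aromatic ring of carbon, so matching on those counts did not keep the response unchanged at this position. The entering group differs by a sulfur atom and a hydrogen-bond acceptor in the count, but nothing shown here gives a reason for the step.

The fluorine and methyl leave together as the methylsulfanyl enters, so a single swap cannot show which of these changes accounts for the lower number. Aryl groups such as 3-methylphenyl, which keeps the methyl without the fluorine, or 3-methoxyphenyl, which puts oxygen where the sulfur stands, are absent from the compounds shown, so the part played by each atom at this position remains open.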